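The compounds below may be only part of what the source reports. "The series", "measured", "known", "first", "only" and "open" are said of these compounds alone.

Measured in a functional assay on MCF7 cells (Homo sapiens) for inhibition, read by sulforhodamine B assay, with a stated time of 48 h; a lower number here means a stronger inhibitor of growth, a higher number a weaker inhibitor of growth:
compound 1 `COc1ccc2c(c1)NC(=O)CN2c1nc(COC(C)=O)nc2ccccc12`: 33 nM
compound 2 `COc1ccc2c(c1)NC(=O)CN2c1nc(NCc2ccncc2)nc2ccccc12`: 71.8 nM

Of these two, compound 2 has the higher number and so is the weaker inhibitor of growth. Among the compounds with values here, the single measured step is a 2.2-fold higher number from compound 1 to compound 2 (0.34 log units; beyond the scatter), with ((pyridin-4-yl)methyl)amino in place of acetoxymethyl on an aromatic carbon. That step is modest, though beyond the scatter.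

Compound 3 `CCOc1nc(N2CC(=O)Nc3cc(OC)ccc32)c2ccccc2n1` has not yet been measured. It carries ethoxy in place of ((pyridin-4-yl)methyl)amino on an aromatic carbon, between two ring nitrogen atoms, the same place that changed in the measured step: ethoxy in place of ((pyridin-4-yl)methyl)amino on an aromatic carbon.

Within the data shown here, only that one step bears on the change, and ethoxy itself has not been tested at this place. Compound 1, which also lacks the ((pyridin-4-yl)methyl)amino group, gives 33 nM, so a modest step of similar size towards a lower number is expected in this assay, although a result within the scatter of compound 2 would not be surprising. The expected change is a 1.9-fold lower number from compound 2 to compound 3 (0.28 log units; within the scatter). For compound 3 the estimated value is 38 nM, with an expected range of 11 nM to 130 nM.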

Compound 3, concentration for 50% growth inhibition: 8.59 nM
The estimate for compound 3 lay 4.4-fold (0.65 log units) above the measured number; the measured number lies below the stated range.
By their numbers in this assay, from the lowest: compound 3; then compound 1; then compound 2.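

In this assay ethoxy on the aromatic carbon between two ring nitrogen atoms brings an 8.4-fold lower number from compound 2 to compound 3 (0.92 log units; beyond the scatter) and a 3.8-fold lower number from compound 1 to compound 3 (0.58 log units; beyond the scatter) so this place is shown to allow a lower number than either earlier group gave. Within the data shown here, until now the only step at this place had separated acetoxymethyl from ((pyridin-4-yl)methyl)amino, and it left open whether a group as short as ethoxy, with 3 heavy atoms, no ring and no hydrogen-bond donor, would hold the number at all. Among the three compounds the lowest number belongs to compound 3, and both of its steps lie beyond the scatter, so neither the six-membered aromatic ring of ((pyridin-4-yl)methyl)amino nor the carbonyl of acetoxymethyl is needed for a low number here.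

As far as these compounds go, what methoxy, a longer propoxy chain or an ethylamino group would give at this place stays open, so it cannot yet be said whether the oxygen attached to the ring or the length of the chain goes with the lower number. Why ethoxy gives the lowest number also stays open, as nothing measured here speaks to the cause.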